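Methoxy for methyl on the cyclopropylamide series

The source may hold more compounds than are shown below. What is called first, only, known or untested is meant among the compounds shown, and "the series" means these compounds.

Three cyclopropylamides have been measured in a toxicity assay on the whole organism (strain Icem-CET (SPF Caw)) for cytotoxicity, with Mus musculus as the target; on this read-out lower numbers stand for an effect already at smaller amounts and higher numbers for an effect only at larger amounts of compound. Compound 2 `C/C(C(=O)NC1CC1)=C(\C)c1ccc(C)cc1` gives 280 mg/kg. Compound 1 `COc1ccc(/C(C)=C(/C)C(=O)NC2CC2)cc1` gives 300 mg/kg. Compound 3 `C/C(C(=O)NC1CC1)=C(/C)c1ccc(C)cc1` gives 110 mg/kg.

Compound 2 and compound 3 share every atom and bond and are set apart by the two compounds have the same atoms and bonds and differ only in configuration as drawn: 1 of 1 stereo elements differ; a double bond is drawn Z in compound 2 and E in compound 3; this assay moved a 2.5-fold lower number from compound 2 to compound 3 (0.41 log units; beyond the scatter), a shift that rests on (the fact that compounds 2 and 3 differ only in the configuration as drawn). Compound 1 and compound 2 differ by methoxy in place of methyl on an aromatic carbon, and here this assay moved a 1.1-fold higher number from compound 2 to compound 1 (0.03 log units; within the scatter), so the methoxy left the number essentially where the methyl had it.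

Compound 4 `COc1ccc(/C(C)=C(\C)C(=O)NC2CC2)cc1` has not yet been measured in this assay. It stands to compound 3 as compound 1 stands to compound 2: the difference is methoxy in place of methyl on an aromatic carbon, the same change at the same place. Since that change moved the number by only a 1.1-fold higher number from compound 2 to compound 1 (0.03 log units; within the scatter), a similarly small step is expected from compound 3 to compound 4, namely a 1.1-fold higher number from compound 3 to compound 4 (0.06 log units; within the scatter). Compound 4 is therefore estimated at 125 mg/kg, expected to lie between 60 mg/kg and 260 mg/kg.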

Compound 4, dose for half-maximal effect: 250 mg/kg
Compound 4: middle estimate off by 2.0-fold (0.30 log units), on the low side; measured number inside the range.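

In this assay the change from methyl to methoxy gave a 2.3-fold higher number from compound 3 to compound 4 (0.36 log units; beyond the scatter), and set beside the earlier step, the two cores do not separate: the same change on two cores in this assay, a 1.1-fold higher number (0.03 log units; within the scatter) from compound 2 to compound 1 and a 2.3-fold higher number (0.36 log units; beyond the scatter) from compound 3 to compound 4, 2.1-fold (0.33 log units) apart, within the scatter of two such steps. This means the change carries from one core to the other only in the limited sense that the two steps cannot be told apart; it does not show that the change acts alike on both cores, and with one step within the scatter and the other beyond it, two pairs support no general rule. The configuration of the double bond separated compound 2 from compound 3, but among the methoxy compounds it gave a 1.2-fold lower number from compound 1 to compound 4 (0.08 log units; within the scatter), which lies within the scatter: the fact that compounds 1 and 4 differ only in the configuration as drawn.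

The compounds shown leave open how an amine, a chlorine or an ethyl would fare on the same aromatic carbon. They also leave open whether the picture would hold with a longer chain in place of the cyclopropyl on the amide.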